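This account rests on a few compounds, and the source may have more. Where it says the series, first, only, none or still open, it means among the compounds named here.

Three compounds share one core and differ only in the aryl group attached to the double-bonded chain carbon. Compound 1 `C=CCn1c(=O)/c(=C\c2cccc(Cl)c2)[nH]c(=O)/c1=C\c1ccccc1OC` gives 5500 nM in a functional assay on HeLa cells (Homo sapiens) for cytotoxicity, read by CCK-8 assay, with a stated time of 72 h; on this read-out lower numbers stand for stronger inhibition and higher numbers for weaker inhibition. Compound 2 `C=CCn1c(=O)/c(=C\c2cccc(Cl)c2Cl)[nH]c(=O)/c1=C\c1ccccc1OC` gives 1600 nM in this assay, and compound 3 `C=CCn1c(=O)/c(=C\c2cccc(Br)c2)[nH]c(=O)/c1=C\c1ccccc1OC` gives 5400 nM. Among these three numbers compound 3 stands second highest: its number and that of compound 1 sit within the scatter, as a 1.0-fold lower number from compound 1 to compound 3 (0.01 log units; within the scatter) shows, whereas a 3.4-fold higher number from compound 2 to compound 3 (0.53 log units; beyond the scatter) lies beyond it. Compound 4 `C=CCn1c(=O)/c(=C\c2ccccc2C(F)(F)F)[nH]c(=O)/c1=C\c1ccccc1OC` has not been measured; it carries 2-(trifluoromethyl)phenyl in place of 3-bromophenyl on a double-bonded chain carbon bound to an aromatic carbon. Within the data shown here, no measured step exchanges one aryl group for another bearing a trifluoromethyl group, so nothing bears directly on this change. The nearest guidance is that a 3.4-fold lower number from compound 1 to compound 2 (0.54 log units; beyond the scatter) and a 3.4-fold higher number from compound 2 to compound 3 (0.53 log units; beyond the scatter) are both modest, while a 1.0-fold lower number from compound 1 to compound 3 (0.01 log units; within the scatter) stays within the scatter. On that basis only a small step in this assay is expected for compound 4, leaning toward a lower number because compound 2 shows a 3.4-fold lower number from compound 1 to compound 2 (0.54 log units; beyond the scatter), but the step of a 1.5-fold lower number from compound 3 to compound 4 (0.19 log units; within the scatter) is estimated to stay within the scatter. Compound 4 is therefore expected to give about 3500 nM in this assay, with a plausible range from 1200 nM to 10000 nM.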

Compound 4, half-maximal inhibitory concentration: 4600 nM
Compound 4: middle estimate off by 1.3-fold (0.12 log units), on the low side; measured number inside the range.
By their numbers in this assay, from the lowest: compound 2; then compounds 4, 3 and 1 (each within the scatter of the next).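

In this assay the double-bonded chain carbon accepts 2-(trifluoromethyl)phenyl, with 10 heavy atoms, in place of 3-bromophenyl, with 7, and the result is a 1.2-fold lower number from compound 3 to compound 4 (0.07 log units; within the scatter). The exchange for 3-chlorophenyl reads the same way, with a 1.2-fold lower number from compound 1 to compound 4 (0.08 log units; within the scatter), so three different aryl groups now sit within the scatter of one another, while 2,3-dichlorophenyl stays apart, as a 2.9-fold higher number from compound 2 to compound 4 (0.46 log units; beyond the scatter) shows, and compound 2 is the only one of the four set off from all the others. No measurement here accounts for this pattern.

Still open, as far as these compounds go, is whether a group of another kind on this aryl ring, such as an amine, a hydroxyl or a carboxylic acid, would move the number beyond the scatter in either direction. Also open, from the compounds shown here alone, is whether a plain phenyl ring with no added group would stand with compound 2 or with the other three, and whether the same grouping would hold on other cells.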